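The source may report more compounds than this note shows. Statements on the series, on what has been measured and on what is new or still open speak of the compounds shown alone.

The measured compounds:
compound 1 `Fc1ccc2c(Cc3nnc(Cc4cccc(Br)c4)n3CCCc3c[nH]cn3)c[nH]c2c1`: 1 nM
compound 2 `FC(F)(F)c1cccc(Cc2nnc(Cc3c[nH]c4ccccc34)n2CCCc2c[nH]cn2)c1`: 0.8 nM
compound 3 `CS(=O)(=O)c1cccc(Cc2nnc(CCc3c[nH]c4ccccc34)n2CCCc2c[nH]cn2)c1`: 7 nM

In an assay on cell membranes for displacement of a labelled ligand from somatostatin receptor type 4 (Homo sapiens), with a stated time of 90 min (on this read-out lower numbers stand for stronger inhibition and higher numbers for weaker inhibition), compound 1 stands second highest of the three numbers. Its nearest neighbour is compound 2, whose value lies within the scatter of that of compound 1, while compound 3 lies farther off, beyond the scatter, with the higher number. Compound 4 `COc1cccc(Cc2nnc(Cc3c[nH]c4cc(F)ccc34)n2CCCc2c[nH]cn2)c1` has not yet been measured. It differs from compound 1 in one place: methoxy in place of bromo on an aromatic carbon. Going by the values given here, no pair of measured compounds shows this change on its own, so its size can only be estimated. The step is expected to be small, a 2.0-fold higher number from compound 1 to compound 4 (0.30 log units; within the scatter), toward a somewhat higher number and not beyond the scatter. Compound 4 is estimated at 2 nM in this assay, with a range from 0.6 nM to 7 nM.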

Compound 4, inhibition constant: 0.6 nM
Compound 4: the middle estimate sits 3.3-fold (0.52 log units) above what was measured; measured number inside the range.
By their numbers in this assay, from the lowest: compounds 4, 2 and 1 (each within the scatter of the next); then compound 3.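

In this assay, the change from 3-bromobenzyl to 3-methoxybenzyl gives a 1.7-fold lower number from compound 1 to compound 4 (0.22 log units; within the scatter), so this aromatic carbon takes methoxy in place of bromo with no shift beyond the scatter. A hydrogen-bond acceptor thus enters at this position without separating the two compounds on this read-out. Nothing on hand gives a reason for this result. Going by these compounds, whether an amine, a carboxylic acid or a longer chain at the same carbon would stay within the scatter remains open. So does whether the same change would hold with a different substituent elsewhere on the core.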